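Aryl substituent swap on the compound 2 scaffold

The source may hold more compounds than are shown below. What is called first, only, known or untested is meant among the compounds shown, and "the series" means these compounds.

Compound 2 `C[C@H](Nc1ncnc2[nH]cnc12)c1nn(-c2cccc(S(C)(=O)=O)c2)c2cc(F)ccc12` stands lowest of the three measured compounds in a functional assay on Bel-7402 cells (Homo sapiens) for inhibition, read by sulforhodamine B assay, with a stated time of 72 h, tested at 10 uM (on this read-out lower numbers stand for less inhibition and higher numbers for more inhibition at the one concentration tested (going by the name of the read-out)), where compound 2 gives -16%. Compound 1 `CC[C@H](Nc1ncnc2[nH]cnc12)c1nn(-c2cccnc2)c2cc(F)ccc12` gives 12% in this assay, and compound 3 `C[C@H](Nc1nc(N)nc(N)c1C#N)c1nn(-c2cccc(S(C)(=O)=O)c2)c2cc(F)ccc12` gives 14%; both sit beyond the scatter above compound 2. Compound 1 differs from compound 2 in more than one place, so their two values can only be set side by side. Going by the values given here, the one single-point step available, a number 30 percentage points higher from compound 2 to compound 3 (beyond the scatter), concerns the group on the amine nitrogen and not the aryl ring.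

Compound 4 `C[C@H](Nc1ncnc2[nH]cnc12)c1nn(-c2cccc(F)c2)c2cc(F)ccc12` is reached from compound 2 by fluoro in place of methylsulfonyl on an aromatic carbon. Among the compounds with values here, no measured step touches this position, so there is no direct guide for this assay. With all three measured numbers low at the tested concentration, the change from compound 2 to compound 4 is expected to give a step of a number 10 percentage points higher from compound 2 to compound 4 (within the scatter) at most, that is, nothing beyond the scatter. Compound 4 is estimated at -6%, within -26% to 16%, in this assay.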

Compound 4, a percentage reported as inhibition, at one concentration (the size of the read-out at that concentration, not a potency): -17%
The estimate for compound 4 lay 11 percentage points above the measured number; measured number inside the range.
By their numbers in this assay, from the lowest: compounds 4 and 2 (each within the scatter of the next); then compounds 1 and 3 (each within the scatter of the next).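

In this assay, going by these compounds alone, the change from 3-(methylsulfonyl)phenyl to 3-fluorophenyl gives a number 1 percentage points lower from compound 2 to compound 4 (within the scatter) and is the first reading at this aromatic carbon, which the earlier single-point step on the amine nitrogen did not touch. On this one step, the two numbers cannot be told apart, so fluoro in place of methylsulfonyl shows no difference at this place on the shared core at the single concentration tested. No measured evidence bears on why this swap shows no difference.

From the compounds shown here alone, whether an amine or a carboxylic acid on this aromatic carbon would read differently stays open. Also open, going by these compounds, is whether the same swap would read alike with the group that compound 3 carries on the amine nitrogen, and whether compound 2 and compound 4 would differ at other concentrations.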